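Sulfanyl to Sulfonyl Swap: Expected Whole-Organism Inhibition

A few compounds are considered here, and "the series" means these few. Any claim that something is new, unique, unknown or untested is made for them only; others in the source may bear on it.

Compound 1, `CCOC(=O)c1c(CSc2nccn2C)nc2cc(OC)c(OC)cc2c1-c1ccc(OC)c(OC)c1`, gives 60% in a functional assay on the whole organism for inhibition, with Rattus norvegicus as the target, at a dose of 50 mg/kg by the oral route; on this read-out higher numbers stand for more inhibition at the one dose given (going by the name of the read-out) and lower numbers for less inhibition.
Compound 2, `CCOC(=O)c1c(CSc2nccn2C)nc2cc(OC)c(OC)cc2c1-c1ccc(Cl)cc1`, gives 41% in this assay.
Compound 3, `CCOC(=O)c1c(CSc2nccn2C)nc2cc(OC)c(OC)cc2c1-c1ccccc1`, gives 31% in this assay.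

Compound 1 stands highest of the three numbers; its nearest neighbour is compound 2, with a number 19 percentage points lower from compound 1 to compound 2 (beyond the scatter), and its furthest is compound 3, with a number 29 percentage points lower from compound 1 to compound 3 (beyond the scatter). Between compound 2 and compound 3 the step is a number 10 percentage points lower from compound 2 to compound 3 (within the scatter).

Compound 4, `CCOC(=O)c1c(CS(=O)(=O)c2nccn2C)nc2cc(OC)c(OC)cc2c1-c1ccc(OC)c(OC)c1`, carries one change from compound 1: (1-methyl-1H-imidazol-2-yl)sulfonyl in place of (1-methyl-1H-imidazol-2-yl)sulfanyl on a saturated chain carbon bound to an aromatic carbon. For the measured compounds named here, none of the measured steps touches this position; all three vary the aromatic ring on the other side of the core. There is therefore no measured guide for the size or direction of the step in this assay, and the expectation rests on compound 1 alone, with wide uncertainty. Compound 4 is expected to give 50%, between 25% and 72%, which would mean a number 10 percentage points lower from compound 1 to compound 4 (within the scatter).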

Compound 4, a percentage reported as inhibition, in the whole organism at one dose (the size of the read-out at that dose, not a potency): 56%
Estimate against measurement, compound 4: 6 percentage points below; the measured number falls inside the stated range.
By their numbers in this assay, from the lowest: compounds 3 and 2 (each within the scatter of the next); then compounds 4 and 1 (each within the scatter of the next).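

For the compounds shown here, the swap gives the first reading at this position, as the earlier steps all varied the aromatic ring on the other side of the core. With (1-methyl-1H-imidazol-2-yl)sulfonyl in place of (1-methyl-1H-imidazol-2-yl)sulfanyl, this assay shows a number 4 percentage points lower from compound 1 to compound 4 (within the scatter), so the two groups cannot be told apart here. No information at hand offers a reason for this result.

The compounds shown leave open whether an amine or a carboxylic acid on the saturated chain carbon would hold up equally well. They also leave open whether the sulfonyl group behaves alike with 4-chlorophenyl or phenyl on the core.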